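The compounds below may be only part of what the source reports. "The series", "measured", "known", "first", "only" and "open" are said of these compounds alone.

Working notes on the series. Two compounds carry numbers in a functional assay on HUVEC cells (Homo sapiens), read by scintillation counting and thymidine incorporation, with a stated time of 24 h; on this read-out higher numbers stand for weaker inhibition and lower numbers for stronger inhibition. Compound 1, `CCC(C)n1ncn(-c2ccc(N3CCN(c4ccc(OC[C@@H]5COC(c6ccc(Cl)cc6Cl)O5)cc4)CC3)cc2)c1=O`, gives 328 nM in this assay. Compound 2, `CCC(C)n1ncn(-c2ccc(N3CCN(c4ccc(OC[C@@H]5CO[C@@](CN6CCNCC6)(c6ccc(Cl)cc6Cl)O5)cc4)CC3)cc2)c1=O`, gives 608 nM in this assay. Compound 2 and compound 1 sit within the scatter of each other, so no order between the two can be read from their numbers.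

Compound 3, `CCc1nccn1C[C@@]1(c2ccc(Cl)cc2Cl)OC[C@@H](COc2ccc(N3CCN(c4ccc(-n5cnn(C(C)CC)c5=O)cc4)CC3)cc2)O1`, has not yet been measured in this assay. It differs from compound 2 in one place: 2-ethyl-1H-imidazol-1-yl in place of piperazin-1-yl on a saturated chain carbon bound to a saturated ring carbon. Within the data shown here, nothing among the measured compounds shows what this kind of exchange does on the shared core. Among the measured compounds shown here, only the step from compound 1 to compound 2 exists, and that step lies within the scatter, so the expected effect of the present change is small, without a clear direction.

The step from compound 2 to compound 3 is expected to be a 1.2-fold lower number from compound 2 to compound 3 (0.08 log units; within the scatter), no more than the scatter allows. Compound 3 is therefore estimated at 500 nM in this assay, within a range from 200 nM to 1500 nM.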

Compound 3, half-maximal inhibitory concentration: 224 nM
The estimate for compound 3 lay 2.2-fold (0.35 log units) above the measured number, within the range that was stated.
By their numbers in this assay, from the lowest: compounds 3, 1 and 2 (each within the scatter of the next, the first and the last beyond it).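

In this assay, 2-ethyl-1H-imidazol-1-yl in place of piperazin-1-yl on a saturated chain carbon bound to a saturated ring carbon gives a 2.7-fold lower number from compound 2 to compound 3 (0.43 log units; beyond the scatter), a modest step that shows this position can respond to the group it carries. The exchange replaces a six-membered non-aromatic ring bearing 1 hydrogen-bond donor with a five-membered aromatic ring bearing 0 hydrogen-bond donors, so ring type and donor count change together in this single step. No measurement among the data bears on why the number falls, and the step stands without an explanation.

The compounds shown do not separate the contribution of the ethyl group from that of the ring, as none carries unsubstituted imidazol-1-yl at this place. From the compounds shown here alone, whether morpholin-4-yl or dimethylamino would follow the same direction also remains open.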